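Methyl on the phenyl ring and tolerance of liver cells

The source may report more compounds than this note shows. Statements on the series, on what has been measured and on what is new or still open speak of the compounds shown alone.

The study measures tolerance of compounds in an ADME assay on L02 cells (Homo sapiens) for cytotoxicity, read by MTT assay, with a stated time of 24 h; a higher number here means that more compound is tolerated, a lower number that less compound is tolerated. Compound 1 `O=c1[nH]cc(S(=O)(=O)Nc2ccccc2-c2cn(-c3cccc(Cl)c3)nn2)c(=O)[nH]1` gives a value of > 100000 nM, which is a limit of this assay and not a number. Compound 2 `Cc1cccc(-n2cc(-c3cccc(NS(=O)(=O)c4c[nH]c(=O)[nH]c4=O)c3)nn2)c1` gives 28300 nM in this assay. Compound 3 `O=c1[nH]cc(S(=O)(=O)Nc2ccc(-c3cn(-c4ccccc4)nn3)cc2)c(=O)[nH]1` is reported as "not toxic" (no number reported) in this assay, so no number stands for it. Going by the values given here, of the three values shown, the one for compound 1 sits at a limit of this assay (the limit of > 100000 nM in this assay, at which 1 of the 3 values shown sits). The only number shown thus belongs to compound 2 alone. Among the compounds with values here, no step between measured compounds is given, so only the values themselves can be compared.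

Compound 4 `Cc1ccccc1-n1cc(-c2ccc(NS(=O)(=O)c3c[nH]c(=O)[nH]c3=O)cc2)nn1` differs from compound 3 by methyl in place of hydrogen on an aromatic carbon, on an aromatic carbon ortho to a large group. Within the data shown here, no step in this assay has been measured for a change of this kind; a difference of a single methyl group is expected to produce no step beyond the scatter, in either direction. Compound 4 is therefore estimated to give 80000 nM in this assay, within a range from 20000 nM to 200000 nM, with a fair chance that only a limit is reported.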

Compound 4, half-maximal cytotoxic concentration: "not toxic" (no number reported)
Nothing numeric was reported for compound 4, and the estimate cannot be compared.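

Compound 3 and compound 4 are both reported in this assay as not toxic, without a number, so no step can be read between them, and nothing given here accounts for this result. The compounds shown leave open whether going from phenyl to 2-methylphenyl changes tolerance at all.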